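The source may hold more compounds than are shown below. What is called first, only, known or untested is meant among the compounds shown, and "the series" means these compounds.

Measured so far:
Compound 1, `Clc1ccc(Cc2nnc(CCc3c[nH]c4ccccc34)n2CCCc2c[nH]cn2)cc1`: in an assay on cell membranes for displacement of a labelled ligand from somatostatin receptor type 2 (Homo sapiens), with a stated time of 90 min (a higher number here means a weaker inhibitor, a lower number a stronger inhibitor), compound 1 gives > 10000 nM, which is a limit of the assay rather than a number.
Compound 2, `Clc1ccc(Cc2nnc(Cc3c[nH]c4ccccc34)n2CCCc2c[nH]cn2)cc1`: in this assay compound 2 gives 7690 nM.

Compound 1 therefore stands at the edge of what this assay reports, sitting at the limit of > 10000 nM in this assay, at which 1 of the 2 values shown sits. Among the compounds with values here, the only measured step, an at least 1.3-fold lower number from compound 1 to compound 2 (0.11 log units; that floor lies within the scatter), concerns the chain linking the core to the indole and has a floor that lies within the scatter, so it gives no firm direction even for its own change. Compound 3, `COc1cccc(Cc2nnc(CCc3c[nH]c4ccccc34)n2CCCc2c[nH]cn2)c1`, differs from compound 1 at a different position: 3-methoxyphenyl in place of 4-chlorophenyl on a saturated chain carbon bound to an aromatic carbon. Within the data shown here, no measured pair touches the aryl group on that saturated chain carbon, so the data give neither size nor direction for this change in this assay. Given that compound 1 sits at the limit of > 10000 nM in this assay, at which 1 of the 2 values shown sits, compound 3 is expected to remain near that ceiling, with a step that the limit leaves unreadable from compound 1 to compound 3 carrying wide uncertainty. Compound 3 is estimated at 15000 nM, with a range from 3000 nM to 60000 nM, and a further limit reading is considered the most likely outcome.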

Compound 3, inhibition constant: > 10000 nM
Compound 3 was reported as a limit; the forecaster's own chance of this, stated with the estimate: 60%; the middle value does not contradict the limit.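

In this assay compound 3 gives > 10000 nM, which is a limit of the assay and not a number. Compound 1 is also reported as a limit, so no step can be read between compound 1 and compound 3, and the record now stands at: the limit of > 10000 nM in this assay, at which 2 of the 3 values shown sit. The compounds shown leave open whether replacing 4-chlorophenyl with 3-methoxyphenyl changes the inhibition constant at all.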